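The source may report more compounds than this note shows. Statements on the series, on what has been measured and on what is new or still open speak of the compounds shown alone.

Working notes on the series. In an ADME assay on HepG2 2.2.15 cells (Homo sapiens) for cytotoxicity, read by CCK-8 assay, with a stated time of 8 days (on this read-out lower numbers stand for higher toxicity in this test and higher numbers for lower toxicity in this test), compound 1 (`Cc1cccc(-c2cc(NC(=O)c3ccc(Cl)cc3O)c[nH]c2=O)c1`) gives 33100 nM and compound 2 (`Cc1cccc(-c2cc(NC(=O)c3ccc(F)cc3O)c[nH]c2=O)c1`) gives 37200 nM while compound 3 (`Cc1cccc(-c2cc(NC(=O)c3ccc(C(F)(F)F)cc3O)c[nH]c2=O)c1`) gives 24200 nM in the same test. Compound 2 is not separated from the other two: its steps (a 1.1-fold higher number from compound 1 to compound 2 (0.05 log units; within the scatter); a 1.5-fold lower number from compound 2 to compound 3 (0.19 log units; within the scatter)) lie within the scatter, and so does the remaining one (a 1.4-fold lower number from compound 1 to compound 3 (0.14 log units; within the scatter)).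

Compound 4 (`CCOc1ccc(-c2cc(NC(=O)c3ccc(F)cc3O)c[nH]c2=O)cc1`) carries 4-ethoxyphenyl in place of 3-methylphenyl on an aromatic carbon. All three measured steps exchange chloro, fluoro and trifluoromethyl elsewhere in the molecule, so they bear on this change only indirectly. No step at this place has been measured, and the range is kept wide for that reason. With so little to go on, no shift beyond the scatter is expected in this assay and the estimated step is small (a 1.2-fold lower number from compound 2 to compound 4 (0.07 log units; within the scatter)). The estimate for compound 4 is 32000 nM (expected range 13000 nM to 75000 nM).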

Compound 4, half-maximal cytotoxic concentration: 51500 nM
For compound 4 the middle estimate is 1.6-fold (0.21 log units) below the measured one; low and high end bracket the measured number.
By their numbers in this assay, from the lowest: compounds 3, 1, 2 and 4 (each within the scatter of the next, the first and the last beyond it).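

In this assay, within the data shown here, the only measured exchange at this place, on an aromatic carbon of a six-membered aromatic ring with 1 nitrogen, gives a 1.4-fold higher number from compound 2 to compound 4 (0.14 log units; within the scatter) and so does not separate the two compounds. The earlier steps shown here varied only chloro, fluoro and trifluoromethyl elsewhere in the molecule; this pair shows that 4-ethoxyphenyl, with 9 heavy atoms against 7 and 1 hydrogen-bond acceptor against 0 for 3-methylphenyl, also stays within the scatter when fluoro is held fixed. Nothing at hand accounts for the two aryl groups reading alike.

Going by these compounds, whether 4-ethoxyphenyl behaves the same with chloro or trifluoromethyl in the other ring remains open. On these data alone, it is equally open whether an amine, a carboxylic acid or a longer alkoxy chain on this phenyl ring would move the number beyond the scatter.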